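The source may hold more compounds than are shown below. What is called first, only, known or untested is meant among the compounds shown, and "the series" means these compounds.

Compound 1 `Cn1cc(-c2ccncc2/C=C/C(N)=O)cn1`; compound 2 `Cn1cc(-c2ccncc2/C=C/C(=O)Nc2ccccc2)cn1`; compound 3 `Cn1cc(-c2ccncc2/C=C/C(=O)Nc2ccc(CN3CC4CC3CO4)cc2)cn1`; compound 4 `O=C(/C=C/c1cnccc1-c1cnn(C2CC2)c1)Nc1ccc(CN2CC3CC2CO3)cc1`, not yet measured.

In an assay for binding affinity to CDK8/Cyclin C (Homo sapiens), read by TR-FRET, with a stated time of 60 min (on this read-out higher numbers stand for weaker inhibition and lower numbers for stronger inhibition), compound 1 reaches only a limit, > 10000 nM, which is the limit of > 10000 nM in this assay, at which 1 of the 3 values shown sits. Compound 2 gives 51 nM and compound 3 gives 16 nM, the lowest number among the measured compounds. Compound 4 differs from compound 3 by cyclopropyl in place of methyl on an aromatic nitrogen. Within the data shown here, the two measured steps, an at least 190-fold lower number from compound 1 to compound 2 (2.29 log units; beyond the scatter) and a 3.2-fold lower number from compound 2 to compound 3 (0.50 log units; beyond the scatter), both concern the amide-type nitrogen end of the shared core; neither touches the group on the aromatic nitrogen, so no measured step bears directly on this change. The step from compound 3 to compound 4 is therefore expected to be small, a 1.2-fold lower number from compound 3 to compound 4 (0.09 log units; within the scatter), within the scatter. Compound 4 is estimated at 13 nM, with a range of 4 nM to 40 nM.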

Compound 4, half-maximal inhibitory concentration: 9.6 nM
Compound 4: the middle estimate sits 1.4-fold (0.13 log units) above what was measured; the range from low to high includes it.
By their numbers in this assay, from the lowest: compounds 4 and 3 (each within the scatter of the next); then compound 2. At a limit, above all of these: compound 1.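

Cyclopropyl in place of methyl on the aromatic nitrogen gives a 1.7-fold lower number from compound 3 to compound 4 (0.22 log units; within the scatter) in this assay, the first reading at this position, since the earlier steps all concerned the amide-type nitrogen end of the shared core. The three-membered ring of carbon is thus accepted here with no change beyond the scatter. Nothing shown gives a cause for this reading.

From the compounds shown here alone, whether this position also accepts a cyclobutyl ring, a longer chain such as n-butyl, or a chain ending in an amine stays open. So does whether the same change reads alike on compound 2.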